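This account rests on a few compounds, and the source may have more. Where it says the series, first, only, none or still open, it means among the compounds named here.

Among the compounds with values here, compound 1 `COc1ccc(-n2c(SC(C)C(=O)Nc3nc(C)c(Br)cc3Br)nc3ccccc32)cc1` is the only member of this small set with a number in an ADME assay on Vero cells (Chlorocebus sabaeus) for cytotoxicity, read by MTT assay, with a stated time of 24 h (on this read-out lower numbers stand for higher toxicity in this test and higher numbers for lower toxicity in this test), where compound 1 gives 9700 nM. A second compound, compound 2 `Cc1ccc(NC(=O)[C@H](C)Oc2nc3ccccc3n2Cc2ccccc2)c(Cl)c1`, carries a different core, and in this assay compound 2 is recorded as "not determined" (no result reported). Compound 1 therefore stands alone as the single measured point and cannot be ranked against anything. The compound that follows is compound 3 `COc1ccc(-n2c(SC(C)C(=O)Nc3ccc(C)cc3Cl)nc3ccccc32)cc1`, which keeps the core of compound 1 and differs from it in one place: 2-chloro-4-methylphenyl in place of 3,5-dibromo-6-methylpyridin-2-yl on an amide-type nitrogen. Within the data shown here, no step between two measured compounds is available to guide the expectation, so the estimate rests on the single value of compound 1 alone. Because compound 1 already shows 9700 nM, a change limited to the group on the amide-type nitrogen is expected to move the result by no more than the ordinary scatter, with no clear direction. The step is accordingly estimated at a 1.4-fold higher number from compound 1 to compound 3 (0.16 log units; within the scatter). Compound 3 is therefore expected to show 14000 nM in this assay, with a range from 5000 nM to 45000 nM.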

Compound 3, half-maximal cytotoxic concentration: > 75000 nM
Compound 3: a limit, no number; the forecaster's own chance of this, stated with the estimate: 25%; middle value at least 5.3-fold (0.72 log units) from the limit.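

Compound 3 gives a limit and not a number in this assay: the limit of > 75000 nM in this assay, at which 1 of the 3 values shown sits. Compound 1 alone could not show whether the group on the amide-type nitrogen matters in this test, but replacing 3,5-dibromo-6-methylpyridin-2-yl with 2-chloro-4-methylphenyl at that place gives an at least 7.7-fold higher number from compound 1 to compound 3 (0.88 log units; beyond the scatter). With the rest of the molecule unchanged, this single pair shows that the change at this position goes with lower toxicity in this test, and it fixes the direction of the step but not its full size.

The pair leaves open which part of the exchange goes with the step, since the ring nitrogen, the two bromines and the chlorine all differ at once between compound 1 and compound 3. It also leaves open how other groups on the amide-type nitrogen would read in this assay, such as an unsubstituted phenyl or a phenyl carrying a carboxylic acid.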